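Three Cyclic Ureas and an Aryl Thiophene Variant

The source may report more compounds than this note shows. Statements on the series, on what has been measured and on what is new or still open speak of the compounds shown alone.

The three measured compounds share a cyclic urea core carrying an aromatic ring on one nitrogen, and all were tested in an assay on RBL-1 cells for inhibition of Polyunsaturated fatty acid 5-lipoxygenase (Rattus norvegicus); a lower number here means a stronger inhibitor, a higher number a weaker inhibitor. Compound 1 `O=C1NCCN(c2cccc([N+](=O)[O-])c2)N1` gives 49000 nM. Compound 3 `O=C1NCCN(c2cccc(Cl)n2)N1` gives 5600 nM. Compound 2 `Cc1cccc(N2CC(C)NC(=O)N2)c1` gives 19000 nM, which places it second highest of the three numbers: its nearest neighbour is compound 1, whose number is higher by a margin beyond the usual scatter, and the furthest is compound 3, whose number is lower, again beyond the scatter.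

Compound 4 `CC1CN(c2cccc(-c3cccs3)c2)NC(=O)N1` has not yet been measured in this assay. It differs from compound 2 in one place: thiophen-2-yl in place of methyl on an aromatic carbon. For the measured compounds named here, no step between measured compounds that differ in one place is available, so nothing in the data shows how such an exchange moves the read-out. The expectation therefore rests on compound 2 alone. Compound 4 is expected to give a somewhat lower number than compound 2, with the step of a 2.7-fold lower number from compound 2 to compound 4 (0.43 log units; beyond the scatter) estimated as modest and only just beyond the scatter. The estimate for compound 4 in this assay is 7000 nM, with a range from 1500 nM to 30000 nM.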

Compound 4, half-maximal inhibitory concentration: 2800 nM
Beside the measured number, compound 4's estimate is 2.5-fold (0.40 log units) above it, within the range that was stated.
By their numbers in this assay, from the lowest: compounds 4 and 3 (each within the scatter of the next); then compound 2; then compound 1.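

In this assay, for the compounds shown here, putting thiophen-2-yl in place of methyl on an aromatic carbon gives a 6.8-fold lower number from compound 2 to compound 4 (0.83 log units; beyond the scatter) and provides the first step in this set between compounds that differ in one place. The step shows that this position, meta to a group of 8 heavy atoms on the six-membered aromatic ring of carbon only, tolerates a group of 5 heavy atoms in place of 1, and that for this pair the larger group, with its five-membered aromatic ring, goes with a lower number rather than a higher one. Nothing measured here accounts for the size or direction of this step.

Going by these compounds, the pair cannot separate the contribution of the ring from that of its sulfur, so it remains open how phenyl or furan-2-yl would compare with thiophen-2-yl at this position, or how an amine, a carboxylic acid or a longer alkyl chain would behave there. On these data alone, it is also open whether the same exchange would move the number in the same direction on the core of compound 1, which lacks the methyl carried by the core of compound 2.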